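Adding a chloro group to compound 1

The compounds below may be only part of what the source reports. "The series", "measured", "known", "first", "only" and "open" are said of these compounds alone.

Values in a functional assay on MCF7 cells (Homo sapiens) for antiproliferative activity, read by MTT assay, with a stated time of 48 h; a higher number here means a weaker inhibitor, a lower number a stronger inhibitor
- Compound 1 `O=[N+]([O-])c1cc(C(F)(F)F)cc([N+](=O)[O-])c1Oc1ccccc1/C=N\OCc1ccccc1F` gives 700 nM
- Compound 2 `O=[N+]([O-])c1cc(C(F)(F)F)cc([N+](=O)[O-])c1Oc1ccccc1/C=N/OCc1ccccc1Cl` gives 1100 nM
- Compound 3 `O=[N+]([O-])c1cc(C(F)(F)F)cc([N+](=O)[O-])c1Oc1ccc(Cl)cc1/C=N\OCc1ccccc1F` is not yet measured

Compound 1 stands level with compound 2, as the two lie within the usual scatter. Compound 3 differs from compound 1 by one change, (chloro in place of hydrogen on an aromatic carbon), chloro in place of hydrogen on an aromatic carbon. Within the data shown here, the only measured step, a 1.6-fold higher number from compound 1 to compound 2 (0.20 log units; within the scatter), is a different change elsewhere in the molecule, so it bears only weakly here. Among the measured compounds shown here, no measured step adds chloro at this place, so no shift beyond the scatter in this assay is expected, in either direction. The expected size is no change at the digits printed from compound 1 to compound 3 (within the scatter) in this estimate. For compound 3 the estimated value is 700 nM, with an expected range from 250 nM to 2000 nM as the likely span.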

Compound 3, half-maximal inhibitory concentration: 1110 nM
Beside the measured number, compound 3's estimate is 1.6-fold (0.20 log units) below it; the measured number falls inside the stated range.
By their numbers in this assay, from the lowest: compounds 1, 2 and 3 (each within the scatter of the next).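

Putting chloro in place of hydrogen on this aromatic carbon, meta to a large group and para to a large group, gives a 1.6-fold higher number from compound 1 to compound 3 (0.20 log units; within the scatter) in this assay. Among these compounds, the earlier pair differed elsewhere in the molecule, so this is the first sign that this position can carry a chlorine atom with no shift beyond the scatter. Nothing measured here speaks to the reason for this result.

From the compounds shown here alone, whether an amine, a methoxy group or a carboxylic acid at this place would also stay within the scatter remains open. So does whether chloro here would give the same result on compound 2.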